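A few compounds are considered here, and "the series" means these few. Any claim that something is new, unique, unknown or untested is made for them only; others in the source may bear on it.

Measured compounds in an ADME assay on HEK293 cells (Homo sapiens) for cytotoxicity, read by CCK-8 assay and cell counting, with a stated time of 2 days; on this read-out higher numbers stand for weaker inhibition and lower numbers for stronger inhibition:

compound 1 `Oc1ccc(-c2cc(-c3ccccn3)nc(-c3ccccc3Cl)c2)cc1` — "not determined" (no result reported)
compound 2 `Oc1ccc(-c2cc(-c3ccccc3)nc(-c3ccccc3Cl)c2)cc1` — 3930 nM
compound 3 `Oc1cccc(-c2cc(-c3ccccn3)nc(-c3ccccc3Cl)c2)c1` — "not determined" (no result reported)

Compound 1 has no single number in this assay, and compound 3 stands in the same position, with no result reported. Only compound 2 carries a value, and in this assay compound 2 gives 3930 nM. Compound 1 therefore cannot be placed on the numbers shown, and no step between measured compounds is available.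

Compound 4 `Oc1ccc(-c2cc(-c3ccc(Cl)cc3)nc(-c3ccccn3)c2)cc1` differs from compound 1 in one place: 4-chlorophenyl in place of 2-chlorophenyl on an aromatic carbon. Among the compounds with values here, since no step between measured compounds has been recorded, the size of this change in this assay is unknown, and nothing in the data points to a direction; the expectation is that any shift stays within the scatter, with the value of compound 2 in this assay as the only anchor. For compound 4 the estimated value in this assay is 4000 nM, with a range from 1000 nM to 20000 nM.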

Compound 4, half-maximal inhibitory concentration: 27200 nM
For compound 4 the middle estimate is 6.8-fold (0.83 log units) below the measured one, and the stated range ends below it.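

No new step can be read between compound 1 and compound 4 in this assay, where compound 1 gives "not determined" (no result reported) and compound 4 gives 27200 nM here. The compounds shown leave open what 4-chlorophenyl in place of 2-chlorophenyl does to this value, and no evidence bears on the result.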